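The source may hold more compounds than are shown below. What is called first, only, known or untested is meant among the compounds shown, and "the series" means these compounds.

Measured compounds in a functional assay on KYSE-450 cells (Homo sapiens) for inhibition, read by MTT assay, with a stated time of 48 h; a lower number here means a stronger inhibitor, a higher number a weaker inhibitor:
compound 1 `C/C=C/C(=O)N(Cc1cccc(O)c1)c1cc(OC)c(OC)c(OC)c1` gives 14700 nM;
compound 2 `COc1ccc(CN(C(=O)CCCl)c2cc(OC)c(OC)c(OC)c2)cc1O` gives 110 nM;
compound 3 `COc1cc(NCc2cccc(O)c2)cc(OC)c1OC` gives 71300 nM.

Compound 2 stands lowest of the three in this assay, with compound 1 and compound 3 both well beyond the scatter above it. Within the data shown here, the only single-place step measured is a 4.9-fold higher number from compound 1 to compound 3 (0.69 log units; beyond the scatter), a loss of the whole acyl group, and it does not test the present change. Compound 4 `C=CC(=O)N(Cc1ccc(OC)c(O)c1)c1cc(OC)c(OC)c(OC)c1` differs from compound 2 by vinyl in place of 2-chloroethyl on a carbonyl carbon. Among the measured compounds shown here, no measured pair isolates a 2-chloroethyl to vinyl exchange on the carbonyl carbon, so nothing supports a step beyond the scatter in either direction. Compound 4 is therefore expected near compound 2, with a 1.1-fold lower number from compound 2 to compound 4 (0.04 log units; within the scatter) as the estimated step; the estimate for compound 4 is 100 nM, range 30 nM to 400 nM.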

Compound 4, half-maximal inhibitory concentration: 160 nM
The estimate for compound 4 lay 1.6-fold (0.20 log units) below the measured number, within the range that was stated.
By their numbers in this assay, from the lowest: compounds 2 and 4 (each within the scatter of the next); then compound 1; then compound 3.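

In this assay, vinyl in place of 2-chloroethyl on a carbonyl carbon gives a 1.5-fold higher number from compound 2 to compound 4 (0.16 log units; within the scatter), so the two groups cannot be told apart at this position. The earlier step removed the whole acyl group, whereas this one keeps the carbonyl and changes only the group on it. No measurement available here bears on why the two groups read alike.

On these data alone, how a longer chain, an amine or a carboxylic acid on this carbonyl carbon would read remains open. Also open, as far as these compounds go, is whether vinyl and 2-chloroethyl would stay level on the core of compound 1.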